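Trimethoxyphenyl amide of the alkynyl aminopyridine core

This account rests on a few compounds, and the source may have more. Where it says the series, first, only, none or still open, it means among the compounds named here.

Measured compounds:
compound 1 `Cc1ccc(C(=O)Nc2cccc(Cl)c2)cc1C#Cc1cc(-c2cnn(C)c2)cnc1N` — 24.8 nM
compound 2 `Cc1ccc(C(=O)Nc2ccc(Cl)cc2)cc1C#Cc1cc(-c2cnn(C)c2)cnc1N` — 269 nM
compound 3 `Cc1ccc(C(=O)Nc2ccc(Cl)cc2Cl)cc1C#Cc1cc(-c2cnn(C)c2)cnc1N` — "not determined" (no result reported)

Within the data shown here, in an ADME assay on RBL-2H3 cells (Rattus norvegicus) for cytotoxicity, read by CCK-8 assay, with a stated time of 24 h (a higher number here means that more compound is tolerated, a lower number that less compound is tolerated), compound 1 gives 24.8 nM and compound 2 gives 269 nM, the step of an 11-fold higher number from compound 1 to compound 2 (1.04 log units; beyond the scatter) being the only measured step. For compound 3 this assay gives "not determined" (no result reported), no single number, so compound 3 cannot be placed on the scale. Compound 4 `COc1cc(NC(=O)c2ccc(C)c(C#Cc3cc(-c4cnn(C)c4)cnc3N)c2)cc(OC)c1OC` differs from compound 3 in one place: 3,4,5-trimethoxyphenyl in place of 2,4-dichlorophenyl on an amide-type nitrogen. Among the measured compounds shown here, no measured step bears on this exchange; the one known step concerns only the position of a single chlorine. The expectation for compound 4 therefore rests on the spread seen across compound 1 and compound 2, with no direction assigned. Compound 4 is expected to give about 300 nM in this assay, within 30 nM to 3000 nM.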

Compound 4, half-maximal cytotoxic concentration: 2.9 nM
The estimate for compound 4 lay 100-fold (2.01 log units) above the measured number, outside the stated range (below it).
By their numbers in this assay, from the lowest: compound 4; then compound 1; then compound 2.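

In this assay, the group on the amide-type nitrogen proves able to move the number well below both chlorophenyl compounds, with a 93-fold lower number from compound 2 to compound 4 (1.97 log units; beyond the scatter) and an 8.6-fold lower number from compound 1 to compound 4 (0.93 log units; beyond the scatter). Compound 4 therefore stands lowest of the three with a number, showing that replacing the chlorophenyl group altogether matters beyond moving a single chlorine. Nothing available accounts for this shift. The step from compound 3 cannot be read, since compound 3 has no number. On these data alone, whether a single methoxy group, an amine or a carboxylic acid on that phenyl ring would give a similar number remains open.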